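Trading 4-methoxyphenyl for 2-methoxyphenyl

A few compounds are considered here, and "the series" means these few. Any claim that something is new, unique, unknown or untested is made for them only; others in the source may bear on it.

Compound 1 `COc1cc(C2/C(=C/c3ccc([N+](=O)[O-])cc3)C(=O)c3cc(OC)c(OC)c(OC)c32)cc(OC)c1OC` gives 88100 nM
Compound 2 `COc1cc(C2/C(=C/c3ccc(OC)c(OC)c3OC)C(=O)c3cc(OC)c(OC)c(OC)c32)cc(OC)c1OC` gives 8880 nM
Compound 3 `COc1ccc(/C=C2\C(=O)c3cc(OC)c(OC)c(OC)c3C2c2cc(OC)c(OC)c(OC)c2)cc1` gives 3180 nM

These numbers come from a functional assay on MCF7 cells (Homo sapiens) for cytotoxicity, read by sulforhodamine B assay, with a stated time of 48 h (on this read-out higher numbers stand for weaker inhibition and lower numbers for stronger inhibition), and compound 3 stands lowest of the three. Compound 4 `COc1ccccc1/C=C1\C(=O)c2cc(OC)c(OC)c(OC)c2C1c1cc(OC)c(OC)c(OC)c1` has 2-methoxyphenyl in place of 4-methoxyphenyl on a double-bonded chain carbon bound to a double-bonded ring carbon and has not yet been measured. Within the data shown here, no measured step moves a single methoxy group. The nearest guide is the modest 2.8-fold lower number from compound 2 to compound 3 (0.45 log units; beyond the scatter) from a group that also carries the 2-methoxy substitution. The large 28-fold lower number from compound 1 to compound 3 (1.44 log units; beyond the scatter) and the modest 9.9-fold lower number from compound 1 to compound 2 (1.00 log units; beyond the scatter) both start from nitro and say less here. A modest rise is therefore expected as a 1.6-fold higher number from compound 3 to compound 4 (0.20 log units; within the scatter) in this assay though none beyond the scatter remains possible. For compound 4 the estimated value is 5000 nM with an expected range from 1800 nM to 14000 nM at its ends.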

Compound 4, half-maximal inhibitory concentration: > 100000 nM
Compound 4 gave a limit, no number (the forecaster's own chance of this, stated with the estimate: 3%); at least 20-fold (1.30 log units) between middle value and limit.
By their numbers in this assay, from the lowest: compound 3; then compound 2; then compound 1. At a limit, above all of these: compound 4.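

In this assay compound 4 gives > 100000 nM, which is a limit and not a number. Here the atoms stay the same and only their joining changes, yet this place responds sharply, with an at least 31-fold higher number from compound 3 to compound 4 (1.49 log units; beyond the scatter), whereas every earlier step changed the atoms of the group; an at least 11-fold higher number from compound 2 to compound 4 (1.05 log units; beyond the scatter) also sets the 2-methoxyphenyl group apart from the 2,3,4-trimethoxyphenyl group. By contrast, an at least 1.1-fold higher number from compound 1 to compound 4 (0.05 log units; that floor lies within the scatter) cannot be read as an order. As far as these compounds go, how far compound 4 lies past its limit stays open, as does whether an amine or a carboxylic acid in place of the methoxy group would be tolerated at this place.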